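Methoxy to hydroxy: lipophilicity notes on four compounds

This account rests on a few compounds, and the source may have more. Where it says the series, first, only, none or still open, it means among the compounds named here.

Measured values in a physicochemical assay for lipophilicity; a lower number here means a more polar compound, a higher number a more lipophilic compound:
compound 1, `COc1ccc(C2=N[C@@H](C(=O)O)CS2)c(O)c1`: -0.89
compound 2, `COc1ccc(C2=N[C@@](C)(C(=O)O)CS2)c(O)c1OC`: -0.95
compound 3, `COc1ccc(O)c(C2=N[C@@](C)(C(=O)O)CS2)c1`: -0.61

Compound 3 carries the highest of the three numbers. Its value and that of compound 1 lie within the scatter of each other, so no order can be read between those two. Compound 2 sits lower than compound 3 by a gap that is beyond the scatter. For the measured compounds named here, no pair among the three measured compounds differs in only one place, so no single step in this assay is available from the data in hand.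

Compound 4, `C[C@]1(C(=O)O)CSC(c2cc(O)ccc2O)=N1`, is the next to be measured. Against compound 3 it differs by hydrogen in place of methyl on an oxygen on an aromatic ring. The same difference, cut one bond further out, reads methoxy to hydroxy. Going by the values given here, none of the measured compounds shows this exchange on its own, so the expectation rests on the general run of such exchanges rather than on a step. The expected step is a number 0.39 log units lower from compound 3 to compound 4 (beyond the scatter), downward, and beyond the scatter. For compound 4 the estimate in this assay is -1, with a range from -1.5 to -0.5.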

Compound 4, partition coefficient: -1.14
For compound 4 the middle estimate is 0.14 log units above the measured one; low and high end bracket the measured number.
By their numbers in this assay, from the lowest: compounds 4, 2, 1 and 3 (each within the scatter of the next, the first and the last beyond it).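

In this assay, hydrogen in place of methyl on an oxygen on an aromatic ring gives a number 0.53 log units lower from compound 3 to compound 4 (beyond the scatter) as the only single-place step among the compounds shown. The earlier compounds shown here offered no pair differing in one place, so the methoxy to hydroxy exchange now has a size read, not only from the general run of such exchanges. This size rests on one pair of compounds, and no measurement in hand bears on the reason for it.

On these data alone, whether the same exchange gives a step of like size on the core of compound 1 or of compound 2 stays open, since neither compound has a partner differing from it in that one place. Also open, as far as these compounds go, is what an ethyl group, a longer chain or an acetyl group on that same oxygen would give in this assay, and whether the values of such compounds would fall between those of the methoxy and hydroxy compounds or outside them.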